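A few compounds are considered here, and "the series" means these few. Any claim that something is new, unique, unknown or untested is made for them only; others in the source may bear on it.

Measured compounds:
compound 1 `Cc1c(C(=O)Nc2ccc(Oc3ccnc4[nH]ccc34)c(F)c2)nnn1-c1ccccc1` — 350 nM
compound 2 `Cc1c(C(=O)Nc2ccc(Oc3ccnc4[nH]ccc34)cc2)nnn1-c1ccccc1` — 320 nM

In a functional assay on MCF7 cells (Homo sapiens) for cytotoxicity, read by MTT assay, with a stated time of 72 h (a higher number here means a weaker inhibitor, a lower number a stronger inhibitor), compound 1 gives 350 nM and compound 2 gives 320 nM. Among the compounds with values here, the two numbers lie within the scatter of each other, so neither can be set apart; the only measured step, a 1.1-fold lower number from compound 1 to compound 2 (0.04 log units; within the scatter), is the exchange of hydrogen in place of fluoro on an aromatic carbon, and it changes nothing beyond the noise.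

Compound 3 `O=C(Nc1ccc(Oc2ccnc3[nH]ccc23)c(F)c1)c1nnn(-c2ccccc2)c1C(F)(F)F` is not yet measured. It differs from compound 1 by trifluoromethyl in place of methyl on an aromatic carbon. Within the data shown here, no measured step touches this position or this kind of exchange; the fluoro-to-hydrogen step from compound 1 to compound 2 lies on a different ring and gives no guidance on the methyl position. The starting point for compound 3 is therefore the number of compound 1, with a range wide enough to cover a shift in either direction. The estimate for compound 3 in this assay is 400 nM, with a range from 120 nM to 1300 nM; the step of a 1.1-fold higher number from compound 1 to compound 3 (0.06 log units; within the scatter) is expected to be no more than the scatter.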

Compound 3, half-maximal inhibitory concentration: 1150 nM
Compound 3: middle estimate off by 2.9-fold (0.46 log units), on the low side; the measured number falls inside the stated range.
By their numbers in this assay, from the lowest: compounds 2 and 1 (each within the scatter of the next); then compound 3.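

In this assay the exchange at the aromatic carbon of the five-membered aromatic ring with 3 nitrogen gives a 3.3-fold higher number from compound 1 to compound 3 (0.52 log units; beyond the scatter) with trifluoromethyl in place of methyl, a modest step toward a weaker inhibitor. The earlier exchange of fluoro for hydrogen gave only a 1.1-fold lower number from compound 1 to compound 2 (0.04 log units; within the scatter) and so left the series without any single change that moved the number beyond the scatter; this position is the first place in the compounds shown where one does, and methyl is the better of the two groups tried there. Nothing measured on these compounds gives a reason for the step.

As far as these compounds go, the reading rests on a single pair, so it remains open whether trifluoromethyl in place of methyl carries the same step on the core of compound 2, which has hydrogen in place of the fluoro of compound 1. Also open, from the compounds shown here alone, is how hydrogen, ethyl, chloro or an amine on this aromatic carbon would compare with methyl, and whether any of them would give a lower number than compound 1.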